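Bromo in place of methoxy on the anilino aryl ring

This account rests on a few compounds, and the source may have more. Where it says the series, first, only, none or still open, it means among the compounds named here.

Measured compounds:
- compound 1 `COc1ccc(NC2=CC(=O)c3c(nc4n3[C@H]3OC[C@@H](O)[C@H]3OC4)C2=O)cc1`: in a functional assay on HeLa cells (Homo sapiens) for inhibition, read by sulforhodamine B assay (on this read-out higher numbers stand for weaker inhibition and lower numbers for stronger inhibition), compound 1 gives > 8000 nM, a limit and not a number.
- compound 2 `O=C1C=C(Nc2ccc(C(F)(F)F)cc2)C(=O)c2c1nc1n2[C@H]2OC[C@@H](O)[C@H]2OC1`: in this assay compound 2 gives > 8000 nM, also a limit.
- compound 3 `O=C1C=C(NC2CCCC2)C(=O)c2c1nc1n2[C@H]2OC[C@@H](O)[C@H]2OC1`: in this assay compound 3 gives > 16000 nM, again a limit.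

Compound 1 thus stands at a limit only, with no measured number to place it against the other two; all three values shown are limits, two of them at the limit of > 8000 nM in this assay, at which 2 of the 3 values shown sit, and one at the limit of > 16000 nM in this assay, at which 1 of the 3 values shown sits.

Compound 4 `O=C1C(Nc2ccc(Br)cc2)=CC(=O)c2c1nc1n2[C@H]2OC[C@@H](O)[C@H]2OC1` differs from compound 1 by bromo in place of methoxy on an aromatic carbon. Among the compounds with values here, no measured step exchanges a substituent on this aryl ring. Within the data shown here, the single step between measured compounds, a step that the two limits leave unreadable from compound 2 to compound 3, replaces the whole aryl group and is unreadable in size because both of its ends sit at the limits the limit of > 8000 nM in this assay, at which 2 of the 3 values shown sit, and (the limit of > 16000 nM in this assay, at which 1 of the 3 values shown sits). It therefore gives no direction for the present change.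

With every measured value at a limit, compound 4 is expected to behave as the others, most probably again as a limit; the expected figure for compound 4 in this assay is 12000 nM, within 4000 nM to 40000 nM. The expected step that the limit leaves unreadable from compound 1 to compound 4 is accordingly no change beyond the scatter.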

Compound 4, half-maximal inhibitory concentration: 5220 nM
Estimate against measurement, compound 4: 2.3-fold (0.36 log units) above, within the range that was stated.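

In this assay, within the data shown here, compound 4 gives 5220 nM, the only one of the four values shown that is a number and not a limit, so this series can give a measured read-out with 4-bromophenyl on the amine nitrogen. Bromo in place of methoxy on this aromatic carbon gives an at least 1.5-fold lower number from compound 1 to compound 4 (0.18 log units; that floor lies within the scatter), which shows a direction but does not establish a change beyond the scatter. The true size of this step stays unreadable because compound 1 gives only a limit: the limit of > 8000 nM in this assay, at which 2 of the 4 values shown sit.

Open, as far as these compounds go, is how chloro, a nitrile or a carboxylic acid at the same place on the aromatic ring would read in this assay. Also open, from the compounds shown here alone, is whether the number for compound 4 reflects bromo specifically or would extend to other halogens.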